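The source may hold more compounds than are shown below. What is called first, only, known or untested is meant among the compounds shown, and "the series" means these compounds.

Compound 3 `C/C(=N\Nc1nc2ccccc2nc1Cc1ccccc1)c1ccccn1` gives 91 nM in an assay on isolated protein for inhibition of Amine oxidase [flavin-containing] A (Homo sapiens), read by spectrophotometry (a higher number here means a weaker inhibitor, a lower number a stronger inhibitor), the highest number among the three measured compounds. Compound 1 `COc1ccc(/C(C)=N/Nc2nc3ccccc3nc2Cc2ccccc2)cc1` gives 89 nM in this assay, and the step from it to compound 3 is a 1.0-fold higher number from compound 1 to compound 3 (0.01 log units; within the scatter). Compound 2 `Clc1ccccc1/C=N/Nc1nc2ccccc2nc1Cc1ccccc1` gives 5.8 nM, and the step to compound 3 is a 16-fold higher number from compound 2 to compound 3 (1.20 log units; beyond the scatter). Compound 4 `C/C(=N\Nc1nc2ccccc2nc1Cc1ccccc1)c1cccs1` carries thiophen-2-yl in place of pyridin-2-yl on a carbon with a double bond to nitrogen. Going by the values given here, the only measured step at this same carbon, a 1.0-fold higher number from compound 1 to compound 3 (0.01 log units; within the scatter), was within the scatter; the large step of a 16-fold higher number from compound 2 to compound 3 (1.20 log units; beyond the scatter) concerns the whole group on the aromatic nitrogen and does not directly bear on a swap of one aryl ring for another. A small step is therefore expected, a 1.4-fold lower number from compound 3 to compound 4 (0.15 log units; within the scatter), in no firm direction. Compound 4 is expected to give about 65 nM, between 20 nM and 200 nM.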

Compound 4, half-maximal inhibitory concentration: 64 nM
Estimate against measurement, compound 4: 1.0-fold (0.01 log units) above; the measured number falls inside the stated range.
By their numbers in this assay, from the lowest: compound 2; then compounds 4, 1 and 3 (each within the scatter of the next).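

At the carbon with a double bond to nitrogen, a five-membered ring is tolerated as well as the six-membered ones: thiophen-2-yl in place of pyridin-2-yl gives a 1.4-fold lower number from compound 3 to compound 4 (0.15 log units; within the scatter), and thiophen-2-yl in place of 4-methoxyphenyl gives a 1.4-fold lower number from compound 1 to compound 4 (0.14 log units; within the scatter). The large gap to compound 2 also holds for this ring, at an 11-fold higher number from compound 2 to compound 4 (1.04 log units; beyond the scatter). No supporting data offer an explanation for these results.

Still open, from the compounds shown here alone, is whether that gap follows the chlorine-bearing ring of compound 2 or the absence of the saturated chain carbon. Also open, going by these compounds, is how a piperidine or a carboxylic acid would read at this carbon.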